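Swapping 4-iodophenyl for 3-chlorobenzyl on a shared core

The source may hold more compounds than are shown below. What is called first, only, known or untested is meant among the compounds shown, and "the series" means these compounds.

- Compound 1 `CCN1CCc2c(sc(NC(=O)Nc3cccc(Cl)c3Cl)c2C(N)=O)C1`: 17400 nM
- Compound 2 `CCN1CCc2c(sc(NC(=O)Nc3cccc(C#N)c3)c2C(N)=O)C1`: 10300 nM
- Compound 3 `CCN1CCc2c(sc(NC(=O)Nc3ccc(I)cc3)c2C(N)=O)C1`: 1620 nM

These three numbers come from a functional assay (strain AB) with Danio rerio as the target, read by microscopy, with a stated time of 1 h; on this read-out lower numbers stand for an effect already at smaller amounts and higher numbers for an effect only at larger amounts of compound. The compounds share one core and differ only in the group on an amide-type nitrogen. Compound 3, at 1620 nM, has the lowest number of the three, and the gaps to both others lie beyond the scatter.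

The next compound, compound 4 `CCN1CCc2c(sc(NC(=O)NCc3cccc(Cl)c3)c2C(N)=O)C1`, carries 3-chlorobenzyl in place of 4-iodophenyl on an amide-type nitrogen.

Among the compounds with values here, three measured steps bear on this change. Moving to 3-cyanophenyl gave a 1.7-fold lower number from compound 1 to compound 2 (0.23 log units; within the scatter). Moving to 4-iodophenyl gave an 11-fold lower number from compound 1 to compound 3 (1.03 log units; beyond the scatter) and also a 6.4-fold lower number from compound 2 to compound 3 (0.80 log units; beyond the scatter). Both steps beyond the scatter ended at compound 3, so leaving 4-iodophenyl is expected to give a higher number in this assay, by a modest step. Within the data shown here, no measured compound carries 3-chlorobenzyl, and a step within the scatter remains possible.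

The expected change is a 3.1-fold higher number from compound 3 to compound 4 (0.49 log units; beyond the scatter). For compound 4 the estimate is 5000 nM, with an expected range from 1200 nM to 20000 nM.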

Compound 4, half-maximal effective concentration: > 25000 nM
Compound 4: no number, only a limit; the forecaster's own chance of this, stated with the estimate: 10%; middle value at least 5.0-fold (0.69 log units) away from the limit.
By their numbers in this assay, from the lowest: compound 3; then compounds 2 and 1 (each within the scatter of the next). At a limit, above all of these: compound 4.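

In this assay, compound 4 gives no number, only a limit: the limit of > 25000 nM in this assay, at which 1 of the 4 values shown sits. Even so, the limit is enough to place it, since 3-chlorobenzyl on the amide-type nitrogen gave an at least 15-fold higher number from compound 3 to compound 4 (1.18 log units; beyond the scatter) and an at least 2.4-fold higher number from compound 2 to compound 4 (0.38 log units; beyond the scatter), which shows that this position does not accept every aromatic group equally and that compound 4, the only compound here with a benzyl group rather than a phenyl group, loses the low number of compound 3 entirely. The comparison with the dichlorophenyl group is less firm, with an at least 1.4-fold higher number from compound 1 to compound 4 (0.15 log units; that floor lies within the scatter), so compound 4 cannot be clearly separated from compound 1 on this evidence.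

Compound 4 changes two things at once, the benzyl link and the swap of iodine for chlorine on the ring, so the compounds shown leave open which of the two drives the rise, and how far its true number lies past the limit. A 4-iodobenzyl group or a 3-chlorophenyl group on the same nitrogen would pull these two changes apart.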